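Demethylating the ether of compound 2: what to expect

The source may report more compounds than this note shows. Statements on the series, on what has been measured and on what is new or still open speak of the compounds shown alone.

Measured compounds:
compound 1 `N[C@@](CCc1cccc(Cl)c1)(C(=O)O)C1C[C@@H]1C(=O)O` gives 180 nM in a functional assay on RGT cells for inhibition of metabotropic glutamate receptor 2 (Homo sapiens); on this read-out lower numbers stand for stronger inhibition and higher numbers for weaker inhibition
compound 2 `COc1cccc(CC[C@](N)(C(=O)O)C2C[C@@H]2C(=O)O)c1` gives 430 nM in this assay

Among these two numbers, compound 2 stands highest, and its only neighbour is compound 1, which lies lower by a 2.4-fold higher number from compound 1 to compound 2 (0.38 log units; beyond the scatter) for the swap of methoxy in place of chloro on an aromatic carbon.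

Compound 3 `N[C@@](CCc1cccc(O)c1)(C(=O)O)C1C[C@@H]1C(=O)O` differs from compound 2 by hydrogen in place of methyl on an oxygen on an aromatic ring, that is, methoxy to hydroxy.

Among the measured compounds shown here, the one measured step, from compound 1 to compound 2, exchanges a chloro for a methoxy and moves the number by a 2.4-fold higher number from compound 1 to compound 2 (0.38 log units; beyond the scatter); it shows that this part of the structure is felt by the assay, but it does not involve the oxygen-bound methyl itself. For the measured compounds named here, no measured pair removes that methyl, so its effect is unknown here. The expectation is therefore a number close to that of compound 2, with wide uncertainty on either side. For compound 3 the estimated value in this assay is 350 nM, within 120 nM to 1000 nM, a change of a 1.2-fold lower number from compound 2 to compound 3 (0.09 log units; within the scatter) that is expected to stay within the scatter.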

Compound 3, half-maximal inhibitory concentration: 1000 nM
Estimate against measurement, compound 3: 2.9-fold (0.46 log units) below; the range from low to high includes it.
By their numbers in this assay, from the lowest: compound 1; then compound 2; then compound 3.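

In this assay, taking the methyl off the oxygen on the aromatic ring is felt in its own right: the change gives a 2.3-fold higher number from compound 2 to compound 3 (0.37 log units; beyond the scatter), so the number depends on more than the presence of an oxygen at this place, something the exchange of chloro for methoxy could not show. Swapping the chloro group for a hydroxy group gives a 5.6-fold higher number from compound 1 to compound 3 (0.74 log units; beyond the scatter), so among the three groups shown here, chloro goes with the lowest number and hydroxy with the highest, with each step between them beyond the scatter. Nothing available here accounts for either step.

The three compounds give only three points at a single place on the shared core, so they leave open whether a longer group on the oxygen, such as ethoxy, would bring the number down again or push it further up. They also leave open where an amine or a fluoro in place of the hydroxy would fall relative to chloro, and whether the order seen here would hold on other aromatic carbons.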